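A few compounds are considered here, and "the series" means these few. Any claim that something is new, unique, unknown or untested is made for them only; others in the source may bear on it.

Working notes on the series.

Of the compounds shown here, two have numbers so far. Compound 1 `O=C(Nc1ccccc1C(F)(F)F)C1CCc2ccccc2N1C(=O)c1ccccc1` carries a benzoyl group on the ring nitrogen of the shared core and a trifluoromethyl-substituted anilide; in a functional assay on MDA-MB-231 cells (Homo sapiens) for cytotoxicity, read by sulforhodamine B assay, with a stated time of 72 h (a lower number here means a stronger inhibitor of growth, a higher number a weaker inhibitor of growth), compound 1 gives 5290 nM. Compound 2 `CCCCCCCCC(=O)N1c2ccccc2CCC1C(=O)Nc1ccccc1O` carries an octylcarbonyl group on the same nitrogen and a hydroxy-substituted anilide; in this assay compound 2 gives 54300 nM, the higher of the two numbers, and the gap to compound 1 is beyond the usual scatter.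

Compound 3 `O=C(Nc1ccccc1O)C1CCc2ccccc2N1C(=O)c1ccccc1` has not yet been measured. It differs from compound 2 in one place: phenyl in place of octyl on a carbonyl carbon whose other neighbour is the amide-type nitrogen in the ring. Among the compounds with values here, no step between measured compounds covers this change on its own. Within the data shown here, the only guidance is that compound 1, which carries the benzoyl group, gives 5290 nM, while compound 2 with the octylcarbonyl group gives 54300 nM; the anilide also differs between them, so the comparison is not clean.

The step from compound 2 to compound 3 is expected to lower the number by a 6.0-fold lower number from compound 2 to compound 3 (0.78 log units; beyond the scatter), beyond the scatter. Compound 3 is estimated at 9000 nM, within a range of 2500 nM to 30000 nM.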

Compound 3, concentration for 50% growth inhibition: 4210 nM
Estimate against measurement, compound 3: 2.1-fold (0.33 log units) above; low and high end bracket the measured number.
By their numbers in this assay, from the lowest: compounds 3 and 1 (each within the scatter of the next); then compound 2.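

Phenyl in place of octyl on a carbonyl carbon whose other neighbour is the amide-type nitrogen in the ring gives, in this assay, a 13-fold lower number from compound 2 to compound 3 (1.11 log units; beyond the scatter) with the hydroxy-substituted anilide held constant. Within the data shown here, this is a large step and the first clean reading of this position, which compound 1 and compound 2 could not give on their own, as they differ in two places. With the benzoyl group held constant, hydroxy in place of trifluoromethyl on an aromatic carbon gives a 1.3-fold lower number from compound 1 to compound 3 (0.10 log units; within the scatter) and so stays within the scatter, and no measurement in hand bears on why either change reads as it does.

The compounds shown leave open whether the phenyl-for-octyl step carries over to the trifluoromethyl-substituted anilide, and whether a shorter chain than octyl or a benzyl group on the same carbonyl carbon would read closer to compound 2 or to compound 3. They also leave open whether an amine or a carboxylic acid on that aromatic carbon would stay within the scatter of hydroxy and trifluoromethyl.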